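The source may hold more compounds than are shown below. What is called first, only, known or untested is meant among the compounds shown, and "the series" means these compounds.

In an ADME assay on L6 cells (Rattus norvegicus) for cytotoxicity, read by resazurin assay, with a stated time of 72 h (a higher number here means a weaker inhibitor, a lower number a stronger inhibitor), compound 1 (`CN(C)C12CC(c3ccccc3)C(CN(C(=O)CN3CCCCC3)C1)C(c1ccccc1)C2`) gives 12100 nM, compound 2 (`CN(C)C12CC(c3ccccc3)C(CN(C(=O)CCN3CCCC3)C1)C(c1ccccc1)C2`) gives 11700 nM, and compound 3 (`CN(C)C12CC(c3ccccc3)C(CN(CCN3CCCCC3)C1)C(c1ccccc1)C2`) gives 2920 nM, the lowest number of the three. Compound 4 (`CN1CCN(CCN2CC3C(c4ccccc4)CC(N(C)C)(CC3c3ccccc3)C2)CC1`) differs from compound 3 in one place: 4-methylpiperazin-1-yl in place of piperidin-1-yl on a saturated chain carbon, two bonds along the chain from an amine nitrogen in a ring. For the measured compounds named here, no measured step makes this exact swap. The nearest is a 1.0-fold lower number from compound 1 to compound 2 (0.01 log units; within the scatter), which changed the end ring and its chain together. The larger steps, a 4.1-fold lower number from compound 1 to compound 3 (0.62 log units; beyond the scatter) and a 4.0-fold lower number from compound 2 to compound 3 (0.60 log units; beyond the scatter), replaced the carbonyl-bearing side chain, a change not repeated here. On that evidence, no step beyond the scatter is expected in this assay, and the estimated step is a 1.2-fold higher number from compound 3 to compound 4 (0.08 log units; within the scatter). The expected value for compound 4 is 3500 nM, within a range of 1500 nM to 8500 nM.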

Compound 4, half-maximal inhibitory concentration: 5260 nM
Compound 4: the middle estimate sits 1.5-fold (0.18 log units) below what was measured; low and high end bracket the measured number.
By their numbers in this assay, from the lowest: compounds 3 and 4 (each within the scatter of the next); then compounds 2 and 1 (each within the scatter of the next).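

In this assay, 4-methylpiperazin-1-yl in place of piperidin-1-yl at this chain end gives a 1.8-fold higher number from compound 3 to compound 4 (0.26 log units; within the scatter), so this swap in the end ring, on a side chain without a carbonyl, makes no change that can be told from scatter. The side chain without a carbonyl still gives the lower number with the new ring, with a 2.2-fold lower number from compound 2 to compound 4 (0.35 log units; beyond the scatter) and a 2.3-fold lower number from compound 1 to compound 4 (0.36 log units; beyond the scatter). No measurement shown here gives a reason for these numbers. As far as these compounds go, whether a morpholin-4-yl ring, or a longer chain carrying the same end ring, would shift the number remains open.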